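A few compounds are considered here, and "the series" means these few. Any claim that something is new, unique, unknown or untested is made for them only; others in the source may bear on it.

Measured so far in an ADME assay for permeability, using PAMPA, with a stated time of 30 min, at pH 7.4; a higher number here means that the compound crosses the layer faster, a lower number that the compound crosses the layer more slowly:
compound 1 `COc1cccc(CNCCCNc2ccnc3cc(Cc4cc(C)cc(C)c4)ccc23)c1O` — 23 10^-6 cm/s
compound 2 `COc1ccc(F)cc1CNCCCNc1ccnc2cc(Cc3cc(C)cc(C)c3)ccc12` — 23 10^-6 cm/s

Compound 1 stands level with compound 2 in this assay; the step of no change at the digits printed from compound 1 to compound 2 (within the scatter) shows that exchanging the group on the saturated chain carbon bound to the amine nitrogen left the permeability unchanged within the scatter.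

Compound 3 `COc1cccc(CNCCCNc2ccnc3cc(-c4ccccc4)ccc23)c1O` is not yet measured. It differs from compound 1 at the other end of the shared core: phenyl in place of 3,5-dimethylbenzyl on an aromatic carbon

For the measured compounds named here, no measured step touches this position; the one step in hand, from compound 1 to compound 2, concerns a different part of the molecule and says nothing direct about the aromatic carbon altered here. With both measured values sitting at the same level, the working assumption is that compound 3 stays near compound 1, the expected step of a 1.2-fold lower number from compound 1 to compound 3 (0.06 log units; within the scatter) being no larger than the scatter. Compound 3 is therefore estimated at 20 10^-6 cm/s, within a range of 10 10^-6 cm/s to 40 10^-6 cm/s.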

Compound 3, apparent permeability: 237 10^-6 cm/s
Estimate against measurement, compound 3: 12-fold (1.07 log units) below, and the stated range ends below it.
By their numbers in this assay, from the lowest: compounds 1 and 2 (each within the scatter of the next); then compound 3.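

In this assay the aromatic carbon on the shared core responds strongly where the saturated chain carbon did not: phenyl in place of 3,5-dimethylbenzyl gives a 10-fold higher number from compound 1 to compound 3 (1.01 log units; beyond the scatter) while the exchange at the chain gave no change at the digits printed from compound 1 to compound 2 (within the scatter) on the same scale. By the counts, the two groups at the aromatic carbon share one six-membered aromatic ring of carbon only, 0 hydrogen-bond donors, 0 hydrogen-bond acceptors and no net charge, and differ in size, with 9 heavy atoms leaving and 6 entering. Nothing at hand explains this step.

Open, as far as these compounds go, is how an unsubstituted benzyl or a 3,5-dimethylphenyl would read at this carbon, either of which would separate the two methyl groups from the rest of the change. Also open, from the compounds shown here alone, is whether the 5-fluoro-2-methoxyphenyl end keeps its level alongside phenyl.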